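The source may report more compounds than this note shows. Statements on the series, on what has been measured and on what is new or still open speak of the compounds shown alone.

Working notes on the series, all on the same shared core. Compound 1 `CCCNC(=O)OC[C@H]1OC(n2cnc3c(NC4CCOC4)ncnc32)[C@H](O)[C@@H]1O` gives 235 nM in an assay on DDT1 cells (Cricetulus griseus) for binding affinity to adenosine receptor A1 (Homo sapiens), read by radioligand binding; a lower number here means a stronger inhibitor, a higher number a weaker inhibitor. Compound 2 `O=C(NC1CCCCC1)OC[C@H]1OC(n2cnc3c(NC4CCOC4)ncnc32)[C@H](O)[C@@H]1O` gives 584 nM in this assay, the step being a 2.5-fold higher number from compound 1 to compound 2 (0.40 log units; beyond the scatter). Compound 3 `C=CC/N=C(\S)OC[C@H]1OC(n2cnc3c(NC4CCOC4)ncnc32)[C@H](O)[C@@H]1O` gives 35 nM in this assay, the lowest of the three numbers; the steps to it are a 6.7-fold lower number from compound 1 to compound 3 (0.83 log units; beyond the scatter) and a 17-fold lower number from compound 2 to compound 3 (1.22 log units; beyond the scatter). Compound 4 `CN(C)C(=S)OC[C@H]1OC(n2cnc3c(NC4CCOC4)ncnc32)[C@H](O)[C@@H]1O` is not yet measured and differs from compound 3 by a group of 5 heavy atoms (3 carbon, 1 nitrogen, 1 sulfur; no ring) in place of a group of 6 heavy atoms (4 carbon, 1 nitrogen, 1 sulfur; no ring), on an oxygen on a saturated carbon. The two steps that bear on this position both ran toward the sulfur-containing group and both lowered the number, modestly and largely. Compound 4 keeps the sulfur but loses the donor and one carbon, so a modest rise is expected. Compound 4 is expected near 100 nM, between 30 nM and 400 nM. The expected step is a 2.9-fold higher number from compound 3 to compound 4 (0.46 log units; beyond the scatter).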

Compound 4, inhibition constant: 205 nM
Beside the measured number, compound 4's estimate is 2.1-fold (0.31 log units) below it, within the range that was stated.
By their numbers in this assay, from the lowest: compound 3; then compounds 4 and 1 (each within the scatter of the next); then compound 2.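

Keeping the sulfur does not by itself keep the low number: a 5.9-fold higher number from compound 3 to compound 4 (0.77 log units; beyond the scatter), so the sulfur-containing group of compound 3 cannot be reduced to its sulfur. With a 1.1-fold lower number from compound 1 to compound 4 (0.06 log units; within the scatter), the sulfur-containing group of compound 4 and the propyl group of compound 1 cannot be told apart, while a 2.8-fold lower number from compound 2 to compound 4 (0.45 log units; beyond the scatter) still separates compound 4 from the cyclohexyl group of compound 2. Nothing measured accounts for these steps.

The step from compound 3 to compound 4 changes the hydrogen-bond donor count, the heavy-atom count and the double bonds together, and these remain unseparated. A sulfur-containing group carrying an ethyl chain on its nitrogen, with the nitrogen hydrogen kept, would bear on this.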